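A few compounds are considered here, and "the series" means these few. Any claim that something is new, unique, unknown or untested is made for them only; others in the source may bear on it.

Compound 3 `COc1cc(-c2nn(-c3cccc(NC(=O)Nc4ccc(Cl)c(Cl)c4)c3)cc2-c2ccncc2)ccc1Cl` stands second highest of the three numbers recorded in a functional assay on MDA-MB-468 cells (Homo sapiens) for inhibition, read by sulforhodamine B assay, with a stated time of 48 h (on this read-out higher numbers stand for weaker inhibition and lower numbers for stronger inhibition), where compound 3 gives 570 nM. Its nearest neighbour is compound 1 `COc1cc(-c2nn(-c3cccc(NC(=O)Nc4cc(C(F)(F)F)cc(C(F)(F)F)c4)c3)cc2-c2ccncc2)ccc1Cl`, which in this assay gives 310 nM, a gap that lies within the scatter; furthest off is compound 2 `COc1cc(-c2nn(-c3cccc(NC(=O)c4cccc(C(F)(F)F)c4)c3)cc2-c2ccncc2)ccc1Cl`, which in this assay gives 1320 nM.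

The move to compound 4 `COc1cc(-c2nn(-c3cccc(NC(=O)Nc4cccc(C(F)(F)F)c4)c3)cc2-c2ccncc2)ccc1Cl` is a single change: 3-(trifluoromethyl)phenyl in place of 3,4-dichlorophenyl on an amide-type nitrogen. Among the compounds with values here, no measured step isolates this swap of one aryl group for another on a urea. Within the data shown here, the only step recorded, a 2.3-fold lower number from compound 2 to compound 3 (0.36 log units; beyond the scatter), exchanges the aryl group and at the same time turns an amide into a urea, so it speaks to the aryl change only indirectly. The closer guide is the pair of compounds 1 and 3, whose values sit within the scatter of each other even though their aryl groups differ. On that basis the step from compound 3 to compound 4 is expected to be small, a 1.1-fold lower number from compound 3 to compound 4 (0.06 log units; within the scatter), with no clear direction. Compound 4 is therefore estimated at 500 nM, with a range from 200 nM to 1300 nM.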

Compound 4, half-maximal inhibitory concentration: 600 nM
Estimate against measurement, compound 4: 1.2-fold (0.08 log units) below, and the stated range covers the measured number.
By their numbers in this assay, from the lowest: compounds 1, 3 and 4 (each within the scatter of the next); then compound 2.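

Within this assay, compound 2 and compound 4 carry the same aryl group, so they give the first clean reading of the linker, with a 2.2-fold lower number from compound 2 to compound 4 (0.34 log units; beyond the scatter) on replacing 3-(trifluoromethyl)phenyl on a carbonyl carbon with (3-(trifluoromethyl)phenyl)amino. With the urea kept, the aryl exchange gives a 1.1-fold higher number from compound 3 to compound 4 (0.02 log units; within the scatter) and so does not separate 3,4-dichlorophenyl from 3-(trifluoromethyl)phenyl on the amide-type nitrogen. Replacing one trifluoromethyl with hydrogen gives a 1.9-fold higher number from compound 1 to compound 4 (0.29 log units; within the scatter) and likewise leaves the two compounds unseparated in this series.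

The compounds shown leave open whether a cyclohexyl group or a short alkyl chain on that nitrogen would hold the number at this level. The data offer no independent evidence that explains these steps.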